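This account rests on a few compounds, and the source may have more. Where it says the series, first, only, none or still open, it means among the compounds named here.

Working notes on the series. For the measured compounds named here, in a functional assay on CCRF-CEM cells (Homo sapiens) for inhibition, read by MTT assay, with a stated time of 72 h (on this read-out lower numbers stand for stronger inhibition and higher numbers for weaker inhibition), compound 1 (`COc1cccc(/C=C/C(=O)Nc2cc(OC)c(OC)c(OC)c2)c1`) gives 23400 nM, the highest of the two numbers so far. Compound 2 (`C=C(Br)C(=O)Nc1ccc(/C=C/C(=O)Nc2cc(OC)c(OC)c(OC)c2)cc1`) gives 25 nM, a much lower number and well beyond the scatter. Going by the values given here, no measured pair differing in one place is available, so nothing yet isolates the effect of a single change.

The next compound is compound 3 (`COc1cc(NC(=O)/C=C/c2cccc(N)c2)cc(OC)c1OC`), which carries amino in place of methoxy on an aromatic carbon, meta to a large group: amino in place of methoxy on an aromatic carbon. The change reads as 3-methoxyphenyl to 3-aminophenyl. In this assay, a modest step towards a lower number is expected, possibly not clearing the scatter. The expected size is a 2.0-fold lower number from compound 1 to compound 3 (0.29 log units; within the scatter). Compound 3 is estimated at 12000 nM, with an expected range of 3000 nM to 40000 nM.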

Compound 3, half-maximal inhibitory concentration: 40900 nM
Compound 3: middle estimate off by 3.4-fold (0.53 log units), on the low side, outside the stated range (above it).
By their numbers in this assay, from the lowest: compound 2; then compounds 1 and 3 (each within the scatter of the next).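

For the compounds shown here, the step from methoxy to amino is the first single change that can be read. In this assay, the result is a 1.7-fold higher number from compound 1 to compound 3 (0.24 log units; within the scatter), so at this place, on an aromatic carbon and meta to a large group, the exchange does not separate the two compounds, even though amino brings a hydrogen-bond donor that methoxy lacks. No measurement at hand accounts for this result.

Still open, on these data alone, is whether another group at this place, such as a hydroxyl, an acetamide or a dimethylamino group, would move the number beyond the scatter. Compound 2 differs from compound 1 and from compound 3 in more than one place, so no single change can yet be tied to its number.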